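The source may report more compounds than this note shows. Statements on the series, on what has been measured and on what is new or still open speak of the compounds shown alone.

Compound 1 `Cc1cnc(Nc2ccc(C(C)C)cc2)nc1Nc1nc2ccccc2s1`: in a functional assay on PC-3 cells (Homo sapiens) for antiproliferative activity, read by MTT assay, with a stated time of 48 h (a higher number here means a weaker inhibitor, a lower number a stronger inhibitor), compound 1 gives > 50000 nM, which is a limit of the assay and not a number.
Compound 2 `Cc1cnc(Nc2ccc(S(C)(=O)=O)cc2)nc1Nc1nc2ccccc2s1`: compound 2 gives > 50000 nM, again only a limit.
Compound 3 `Cc1cnc(Nc2ccc([N+](=O)[O-])cc2)nc1Nc1nc2ccccc2s1`: compound 3 gives > 50000 nM, also only a limit.

Compound 3 therefore stands at the same place as the other two, at the edge of what this assay can report, and none of the three can be placed above or below another. The steps a step that the two limits leave unreadable from compound 1 to compound 2, a step that the two limits leave unreadable from compound 1 to compound 3 and a step that the two limits leave unreadable from compound 2 to compound 3 give no size because the limit of > 50000 nM in this assay, at which 3 of the 3 values shown sit, leaves any difference between them hidden.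

Compound 4 `Cc1cnc(Nc2ccc(S(N)(=O)=O)cc2)nc1Nc1nc2ccccc2s1` differs from compound 3 by sulfamoyl in place of nitro on an aromatic carbon. Among the compounds with values here, no measured step involves a sulfamoyl group, so the change has no direct precedent here; the three measured steps bear on it only in that every exchange at this position so far has left the value at the limit. The step from compound 3 is therefore expected to be a number no higher from compound 3 to compound 4 (the limit leaves the size open). For compound 4 the estimate is 50000 nM, with a range from 15000 nM to 150000 nM, and most likely the assay will again report only a limit.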

Compound 4, half-maximal inhibitory concentration: > 50000 nM
Compound 4: no number, only a limit (the forecaster's own chance of this, stated with the estimate: 80%); the middle value sits exactly at the limit.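

Compound 4 sits with compound 1, compound 2 and compound 3 at the edge of what this assay can report, so its steps to all three cannot be read: the limit of > 50000 nM in this assay, at which 4 of the 4 values shown sit.

Going by these compounds, whether any of these four compounds is stronger than another, and whether any other group on that aromatic carbon would give a readable number, stays open.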